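This account rests on a few compounds, and the source may have more. Where it says the series, first, only, none or still open, it means among the compounds named here.

Measured so far:
Compound 1, `Nc1nc(Cl)c2ncn([C@H]3CCCC[C@H]3CO)c2n1`: > 200000 nM
Compound 2, `CCCC#Cc1cn([C@H]2C[C@H](O)[C@@H](CO)O2)c(=O)[nH]c1=O`: > 200000 nM

In an ADME assay on L1210/0 cells (Mus musculus) for cytotoxicity, with a stated time of 48 h (a higher number here means a weaker inhibitor, a lower number a stronger inhibitor), compound 1 gives only a limit, > 200000 nM. Compound 2 likewise gives only a limit in this assay, > 200000 nM. Both results sit at the same point, (the limit of > 200000 nM in this assay, at which 2 of the 2 values shown sit), so compound 2 stands alongside compound 1 rather than apart from it. Compound 3, `O=c1[nH]c(=O)n([C@H]2C[C@H](O)[C@@H](CO)O2)cc1O`, has not yet been tested. It differs from compound 2 by hydroxy in place of pent-1-yn-1-yl on an aromatic carbon. Among the measured compounds shown here, with no measured step to lean on, a step in this assay no larger than the scatter is expected, in no particular direction. Compound 3 is therefore expected to give 300000 nM, within 100000 nM to 1000000 nM. That is expected to mean a step that the limit leaves unreadable from compound 2 to compound 3.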

Compound 3, half-maximal inhibitory concentration: > 200000 nM
Compound 3 was reported as a limit; the forecaster's own chance of this, stated with the estimate: 85%; the middle value lies beyond the limit too.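

Compound 2 and compound 3 each give only a limit, so no step can be read between them: the limit of > 200000 nM in this assay, at which 3 of the 3 values shown sit.

Whether any of the compounds shown would give a readable value in this assay stays open.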